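Replacing the hydroxyethyl arm of compound 1 with a furan-bearing chain

A few compounds are considered here, and "the series" means these few. Any claim that something is new, unique, unknown or untested is made for them only; others in the source may bear on it.

Among the compounds with values here, compound 1 `N=c1c2c(-c3ccccc3)cn(Cc3ccccc3)c2ncn1CCO` was measured in an ADME assay on microsomes from liver (Mus musculus, strain CD1) for metabolic stability, read by LC-MS, using NADPH, with a stated time of 60 min (a higher number here means that the compound lasts longer, a lower number that the compound disappears faster), and gives 0.153 h, the lowest of the two numbers known here. Compound 2 `COc1ccc(Cn2c(-c3ccccc3)c(-c3ccccc3)c3c(=N)n(CCCO)cnc32)cc1` gives 0.332 h in this assay, and the gap between compound 1 and compound 2 lies beyond the scatter. Compound 3 `N=c1c2c(-c3ccccc3)cn(Cc3ccccc3)c2ncn1Cc1ccco1` has not yet been measured; it differs from compound 1 by furan-2-yl in place of hydroxymethyl on a saturated chain carbon bound to an aromatic nitrogen. Within the data shown here, no step between measured compounds speaks to this change, so a step of modest size is expected from compound 1 to compound 3, within the scatter, as a 1.2-fold lower number from compound 1 to compound 3 (0.07 log units; within the scatter). Compound 3 is therefore estimated at 0.13 h in this assay, in a range from 0.06 h to 0.3 h.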

Compound 3, half-life: 0.05 h
Compound 3: middle estimate off by 2.6-fold (0.41 log units), on the high side; the measured number lies below the stated range.
By their numbers in this assay, from the lowest: compound 3; then compound 1; then compound 2.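

In this assay, furan-2-yl in place of hydroxymethyl on a saturated chain carbon bound to an aromatic nitrogen gives a 3.1-fold lower number from compound 1 to compound 3 (0.49 log units; beyond the scatter), so the number does respond to the group at this position. Compound 2 could not show this, as it differs from compound 1 in more than one place. Nothing given here accounts for the step.

The compounds shown leave open whether the lower number goes with the loss of the hydroxyl or with the arrival of the furan ring. They also leave open how an amine or a carboxylic acid on this chain would compare.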